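The source may hold more compounds than are shown below. What is called first, only, known or untested is meant among the compounds shown, and "the series" means these compounds.

Measured so far in an in vitro functional assay on cells for agonist activity at Bombesin receptor subtype-3 (Homo sapiens), read by luminescence and calcium flux; on this read-out higher numbers stand for an effect only at larger amounts of compound and lower numbers for an effect already at smaller amounts:
Compound 1 `O=C(O)c1ccccc1-c1ccc(CCc2ncc(Cc3ccccc3F)[nH]2)cc1` gives 177 nM.
Compound 2 `O=C(O)c1ccccc1-c1ccc(CCc2ncc(Cc3cccc(F)c3)[nH]2)cc1` gives 159 nM.
Compound 3 `CCCCc1cnc(C(CCCO)Cc2ccc(-c3ccccc3C(=O)O)cc2)[nH]1` gives 1900 nM.

Compound 2 has the lowest of these three numbers, though compound 1 sits within the scatter of it; only compound 3 lies clearly higher. Compound 4 `Cc1ccc(Cc2cnc(CCc3ccc(-c4ccccc4C(=O)O)cc3)[nH]2)cc1` differs from compound 2 in one place: 4-methylphenyl in place of 3-fluorophenyl on a saturated chain carbon bound to an aromatic carbon. For the measured compounds named here, the one measured step of the same kind, a 1.1-fold lower number from compound 1 to compound 2 (0.05 log units; within the scatter), exchanged one fluorophenyl for another without a change beyond the scatter. Going by the values given here, compound 3 shares no single-point step with compound 4, so its higher number gives no guide here. Swapping one small aromatic group for another is therefore expected to leave the number roughly where it is, a 1.3-fold higher number from compound 2 to compound 4 (0.10 log units; within the scatter). Compound 4 is estimated at 200 nM, likely between 80 nM and 500 nM.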

Compound 4, half-maximal effective concentration: 2660 nM
For compound 4 the middle estimate is 13-fold (1.12 log units) below the measured one, and the stated range ends below it.
By their numbers in this assay, from the lowest: compounds 2 and 1 (each within the scatter of the next); then compounds 3 and 4 (each within the scatter of the next).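

Replacing a fluorophenyl group with 4-methylphenyl on a saturated chain carbon bound to an aromatic carbon gives a 17-fold higher number from compound 2 to compound 4 (1.22 log units; beyond the scatter) and a 15-fold higher number from compound 1 to compound 4 (1.18 log units; beyond the scatter) in this series. This place therefore responds strongly to the group it carries, even though moving the fluorine alone gave no change beyond the scatter and the entering and leaving groups both have 7 heavy atoms. Nothing available explains this rise. The compounds shown change both the substituent and its ring position, so the methyl group and its position cannot be separated. Neither 3-methylphenyl nor 4-fluorophenyl is among them to settle this.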